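The source may report more compounds than this note shows. Statements on the series, on what has been measured and on what is new or still open speak of the compounds shown alone.

Compounds measured so far in an ADME assay on HepG2 2.2.15 cells (Homo sapiens) for cytotoxicity, read by MTT assay, with a stated time of 8 days; on this read-out higher numbers stand for lower toxicity in this test and lower numbers for higher toxicity in this test:

Compound 1, `COCCNc1nc(F)c(-c2nn(Cc3ccc(C#N)cc3)c(=O)c3ccccc23)cc1Cl`, gives a result that is a limit of the test: > 100000 nM.
Compound 2, `CC(C)c1cc(-c2ccc(F)nc2F)nn(Cc2ccc(Cl)cc2)c1=O`, gives 56700 nM.
Compound 3, `Cc1ccc(-c2nn(Cc3ccc(C#N)cc3)c(=O)c3ccccc23)c(F)n1`, gives a result that is a limit of the test: > 100000 nM.

Compound 3 stands at the edge of what this assay reports: its value is a limit, not a number, and it shares that limit with compound 1, as the limit of > 100000 nM in this assay, at which 2 of the 3 values shown sit, shows. Going by the values given here, only compound 2 returns a number, and compound 2 differs from compound 3 in more than one place, so no single step between measured compounds can be read from these three values.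

Among the compounds with values here, the next compound, compound 4, `N#Cc1ccc(Cn2nc(-c3ccc(N)nc3F)c3ccccc3c2=O)cc1`, is the partner of compound 3 in the one change that is counted here: amino in place of methyl on an aromatic carbon. The group that leaves is methyl and the group that enters is amino, on an aromatic carbon of a six-membered aromatic ring with one nitrogen.

Since compound 3 sits at the limit and compound 1 sits at the same limit, the expectation for this change is no step beyond the scatter in this assay, as a number no higher from compound 3 to compound 4 (the limit leaves the size open) expresses. Compound 4 is accordingly estimated at 100000 nM, with a range from 50000 nM to 300000 nM, and a limit rather than a number is expected to be the likelier outcome.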

Compound 4, half-maximal cytotoxic concentration: > 100000 nM
Compound 4 was reported as a limit (the forecaster's own chance of this, stated with the estimate: 75%); the middle value sits exactly at the limit.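

In this assay compound 4 gives > 100000 nM, which is a limit and not a number. Compound 3 also sits at a limit, so no step can be read between compound 3 and compound 4: the limit of > 100000 nM in this assay, at which 3 of the 4 values shown sit. The compounds shown leave open whether amino in place of methyl changes cytotoxicity at all.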